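Chloro to Amino on a Shared Purine-Type Core

The source may report more compounds than this note shows. Statements on the series, on what has been measured and on what is new or still open speak of the compounds shown alone.

Compound 1 `ClCc1ccccc1Cn1cnc2c(Cl)nc(Cl)nc21` has no single number in a functional assay on COLO 205 cells (Homo sapiens) for cytotoxicity, read by sulforhodamine B assay, with a stated time of 48 h (a higher number here means that more compound is tolerated, a lower number that less compound is tolerated), where for compound 1 the entry reads "not determined" (no result reported). Its companion compound 2 `ClCc1cccc(Cn2cnc3c(Cl)nc(Cl)nc32)c1` stands at a limit of the assay: in this assay compound 2 gives > 100000 nM, a limit and not a number, as shown by the limit of > 100000 nM in this assay, at which 1 of the 2 values shown sits. Compound 3 `Nc1nc(Cl)c2ncn(Cc3ccccc3CCl)c2n1` differs from compound 1 by amino in place of chloro on an aromatic carbon. Within the data shown here, no measured step links these two compounds, so no change beyond the scatter can be predicted in either direction. Compound 3 is therefore expected to give about 100000 nM in this assay, within a range from 20000 nM to 300000 nM.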

Compound 3, concentration lethal to 50% of the cells: > 100000 nM
Compound 3: a limit, no number; the forecaster's own chance of this, stated with the estimate: 60%; the middle value lies on the limit itself.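

No step can be read from compound 1 to compound 3, for compound 1 has no number in this assay and compound 3 sits at a limit: the limit of > 100000 nM in this assay, at which 2 of the 3 values shown sit. The compounds shown leave open whether amino in place of chloro changes the lethal concentration at all.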